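From compound 3 to compound 4: a hydroxymethyl added

The source may report more compounds than this note shows. Statements on the series, on what has been measured and on what is new or still open speak of the compounds shown alone.

Measured in an ADME assay for pharmacokinetics, read by LC-MS, in phosphate buffer, with a stated time of 120 min, at pH 7.4, tested at 1 uM, in the presence of a further agent that is not named here; on this read-out lower numbers stand for a shorter-lived compound and higher numbers for a longer-lived compound:
Compound 1 `C=C(C(=O)Nc1ccccc1)C(F)(F)F`: 0.25 h
Compound 2 `C=C(Cc1ccccc1)C(=O)Nc1ccccc1`: > 8.53 h
Compound 3 `C=C(C)C(=O)Nc1ccccc1`: > 8.53 h

For compound 3, the entry > 8.53 h is a limit of the assay and not a number. For compound 2, the entry > 8.53 h is a limit as well. Compound 3 therefore stands at the limit of > 8.53 h in this assay, at which 2 of the 3 values shown sit.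

The unmeasured compound 4 `C=C(CCO)C(=O)Nc1ccccc1` differs from compound 3 by hydroxymethyl in place of hydrogen on a saturated chain carbon bound to a double-bonded chain carbon. In other words, hydroxymethyl takes the place of hydrogen on a saturated chain carbon bound to a double-bonded chain carbon, turning methyl into 2-hydroxyethyl.

For the measured compounds named here, two measured steps bear on this change. The closer one changes the same saturated chain carbon, and it is a step that the two limits leave unreadable from compound 2 to compound 3. Even with phenyl on that carbon, compound 2 gives a limit and no number. The other is an at least 34-fold higher number from compound 1 to compound 3 (1.53 log units; beyond the scatter), a large step, but it replaces trifluoromethyl on a double-bonded chain carbon bound to a carbonyl carbon, and compound 4 carries no trifluoromethyl.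

No step beyond the scatter is therefore expected in this assay, and a report of only a limit is the likeliest outcome. The estimated step is a step that the limit leaves unreadable from compound 3 to compound 4. For compound 4 the expected half-life is 10 h, within an estimated range of 4.5 h to 25 h.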

Compound 4, half-life: > 8.53 h
Compound 4: no number, only a limit (the forecaster's own chance of this, stated with the estimate: 70%); the middle value does not contradict the limit.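

In this assay compound 4, which carries 2-hydroxyethyl in place of methyl, gives > 8.53 h as its entry, and this is a limit of the assay and not a number. The saturated chain carbon bound to a double-bonded chain carbon has now taken both a phenyl, in compound 2, and a hydroxymethyl, in compound 4, and neither compound gives a measurable half-life, so the steps among compound 2, compound 3 and compound 4 cannot be read. For the compounds shown here, the one readable new step starts from the trifluoromethyl of compound 1 and is an at least 34-fold higher number from compound 1 to compound 4 (1.53 log units; beyond the scatter) and the other compounds gather at one ceiling: the limit of > 8.53 h in this assay, at which 3 of the 4 values shown sit.

On these data alone, how far apart compound 2, compound 3 and compound 4 really lie stays unknown, as does whether any group on this saturated chain carbon can bring the half-life down to a number. As far as these compounds go, an amine, a carboxylic acid or a longer chain at this place remains open, and so does a nitrile in place of trifluoromethyl on the double-bonded chain carbon bound to a carbonyl carbon.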